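Swapping chloro for fluoro in a growth inhibition test

This account rests on a few compounds, and the source may have more. Where it says the series, first, only, none or still open, it means among the compounds named here.

- Compound 1 `O=C(CCCCC(S)CCS)Nc1ccccc1`: 1.32%
- Compound 2 `O=C(CCCCC(S)CCS)Nc1ccc(Cl)cc1`: 0.27%

In a functional assay on Bel-7402 cells (Homo sapiens) for inhibition, read by MTT assay, with a stated time of 24 h, tested at 1 ug/mL (a lower number here means less inhibition of growth, a higher number more inhibition of growth at the concentration tested), compound 2 gives 0.27%, which lies within the scatter of compound 1, so the two cannot be ranked. Compound 3 `O=C(CCCCC(S)CCS)Nc1ccc(F)cc1` has fluoro in place of chloro on an aromatic carbon. Among the measured compounds shown here, only one measured change bears on this, a number 1.1 percentage points lower from compound 1 to compound 2 (within the scatter), which brought chloro onto the ring. With that single small step as a guide, no change beyond the scatter is expected. The expected change is a number 1.7 percentage points higher from compound 2 to compound 3 (within the scatter). Compound 3 is estimated at 2%, with a range of 0% to 10%.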

Compound 3, percent growth inhibition at one concentration: "not active" (no number reported)
The entry for compound 3 holds no number; the estimate stays without a comparison.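

Among the compounds shown here, compound 3 is entered as "not active" without a number, so no step from compound 2 to compound 3 can be read. As far as these compounds go, how fluoro compares with chloro at this ring position stays open. No further evidence bears on this result.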